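A few compounds are considered here, and "the series" means these few. Any claim that something is new, unique, unknown or untested is made for them only; others in the source may bear on it.

Series notes. In a functional assay on MCF7 cells (Homo sapiens) for antiproliferative activity, read by MTT assay, with a stated time of 48 h (a lower number here means a stronger inhibitor, a higher number a weaker inhibitor), compound 1 (`COc1ccc2c(/C=C/C(=O)c3cc(OC)c(OC)c([N+](=O)[O-])c3)c[nH]c2c1`) gives 662 nM and compound 2 (`COc1cc(C(=O)/C=C/c2c[nH]c3ccccc23)cc([N+](=O)[O-])c1OC`) gives 1290 nM. Among the compounds with values here, compound 1 therefore has the lower of only two numbers, but the gap between them does not exceed the scatter: a 1.9-fold higher number from compound 1 to compound 2 (0.29 log units; within the scatter). That step is hydrogen in place of methoxy on an aromatic carbon.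

Next is compound 3 (`COc1ccc2c(/C=C/C(=O)c3cc(OC)c(OC)c([N+](=O)[O-])c3)cn(C)c2c1`), which keeps the core of compound 1 and has one change: methyl in place of hydrogen on an aromatic nitrogen. This is methyl in place of hydrogen on an aromatic nitrogen, two ring bonds from the ring atom that bears a large group.

Within the data shown here, no measured step touches that nitrogen, as both measured compounds carry hydrogen there. Among the measured compounds shown here, the one available step, a 1.9-fold higher number from compound 1 to compound 2 (0.29 log units; within the scatter), lies at a different place and gives only a weak guide to size and none to direction. No shift beyond the scatter is therefore expected in this assay, though the uncertainty is wide. The estimated step is a 1.1-fold lower number from compound 1 to compound 3 (0.04 log units; within the scatter), and neither direction is firmly expected. For compound 3 the expected value is 600 nM, with an estimated range of 180 nM to 2000 nM.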

Compound 3, half-maximal inhibitory concentration: 1520 nM
The estimate for compound 3 lay 2.5-fold (0.40 log units) below the measured number; measured number inside the range.
By their numbers in this assay, from the lowest: compounds 1, 2 and 3 (each within the scatter of the next, the first and the last beyond it).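

In this assay, the aromatic nitrogen of the five-membered ring now has a measured step of its own: a 2.3-fold higher number from compound 1 to compound 3 (0.36 log units; beyond the scatter), for methyl in place of hydrogen. Within the data shown here, this is the first step printed as beyond the scatter, unlike a 1.9-fold higher number from compound 1 to compound 2 (0.29 log units; within the scatter), which lies at a different place, so on the core of compound 1 this position does not accept methyl without a modest rise in the number. No measurement available here bears on the reason for this rise.

The compounds shown give only hydrogen and methyl at this nitrogen, so it remains open whether the number keeps rising with an ethyl group or a longer chain, or whether a hydroxyethyl or aminoethyl chain would behave differently from methyl. From the compounds shown here alone, it also remains open whether the same change gives a step of similar size on the core of compound 2, since that compound has no partner carrying methyl on the nitrogen with everything else kept the same.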